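Hydrazide in place of morpholine on the dichlorophenyl pyrazole amide

The source may hold more compounds than are shown below. What is called first, only, known or untested is meant among the compounds shown, and "the series" means these compounds.

Going by the values given here, compound 2 `O=C(c1cc(-c2ccc(Cl)cc2Cl)n[nH]1)N1CCOCC1` gives the highest number of the three measured so far in an assay on isolated protein for inhibition of alkaline phosphatase, tissue-nonspecific isozyme (Homo sapiens) (on this read-out higher numbers stand for weaker inhibition and lower numbers for stronger inhibition), at 574 nM. Compound 1 `O=C(NCCO)c1cc(-c2ccc(Cl)cc2Cl)n[nH]1` gives 44 nM in this assay, and compound 3 `O=C(NCCO)c1cc(-c2cc(F)c(F)cc2F)n[nH]1` gives 134 nM; both of these open-chain amides sit well under compound 2.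

Compound 4 `NNC(=O)c1cc(-c2ccc(Cl)cc2Cl)n[nH]1` is to be measured. The change from compound 2 is aminoamino in place of morpholin-4-yl on a carbonyl carbon. Among the compounds with values here, the single measured step that bears on it is the one that formed compound 2 from an open-chain amide bearing a donor: a 13-fold higher number from compound 1 to compound 2 (1.12 log units; beyond the scatter). Compound 4 moves the other way, replacing the ring amine with a small open group carrying two donors, so a step of similar size back downward in this assay is expected, though the hydrazide is not identical to the hydroxyethyl amide and a full return to the number of compound 1 is not assured.

For compound 4 the expected step is a 9.6-fold lower number from compound 2 to compound 4 (0.98 log units; beyond the scatter), giving an estimate of 60 nM with a range from 20 nM to 200 nM.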

Compound 4, half-maximal inhibitory concentration: 44 nM
The estimate for compound 4 lay 1.4-fold (0.13 log units) above the measured number; the range from low to high includes it.
By their numbers in this assay, from the lowest: compounds 1 and 4 (each within the scatter of the next); then compound 3; then compound 2.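

In this assay, the step of a 13-fold lower number from compound 2 to compound 4 (1.12 log units; beyond the scatter) shows that a second open group, aminoamino, gives a large drop from the morpholin-4-yl amide, so this drop is not confined to the 2-hydroxyethyl amide. The step of no change at the digits printed from compound 1 to compound 4 (within the scatter) shows that, on this dichlorophenyl core, the amide-type nitrogen accepts amino in place of 2-hydroxyethyl, so the hydroxyethyl chain is not needed to reach this number. No measurement here explains either step.

The compounds shown leave open whether the high number of compound 2 goes with the ring itself or with the missing amide hydrogen, a question that dimethylamino on the same carbonyl carbon would address. Also open, going by these compounds, is how a longer chain such as 3-hydroxypropyl reads there, and whether aminoamino on the core of compound 3 tracks its 2-hydroxyethyl amide.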